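The source may report more compounds than this note shows. Statements on the series, on what has been measured and on what is new or still open speak of the compounds shown alone.

Working notes on the amide series sharing the core of compound 1 `CCn1c(C(=O)N[C@@H](CO)C(C)C)ccc1C(CC)(CC)c1ccc(OCS(=O)(=O)c2ccccc2)c(C)c1`.

In a functional assay on BXPC-3 cells (Homo sapiens) for antiproliferative activity, read by MTT assay, with a stated time of 24 h (on this read-out lower numbers stand for stronger inhibition and higher numbers for weaker inhibition), compound 1 gives 13200 nM, the lowest of the two numbers recorded so far. Compound 2 `CCn1c(C(=O)N[C@@H](C(=O)O)C(C)C)ccc1C(CC)(CC)c1ccc(OCS(=O)(=O)c2ccccc2)c(C)c1` gives 13900 nM in this assay; the step of a 1.1-fold higher number from compound 1 to compound 2 (0.02 log units; within the scatter) shows that carboxy in place of hydroxymethyl on a saturated chain carbon bound to an amide-type nitrogen and a saturated chain carbon leaves the number essentially unchanged. Compound 3 `CCn1c(C(=O)NCCC(=O)O)ccc1C(CC)(CC)c1ccc(OCS(=O)(=O)c2ccccc2)c(C)c1` reaches only the assay limit > 50000 nM in this assay, so its value is a limit and not a number (the limit of > 50000 nM in this assay, at which 1 of the 3 values shown sits). The step of an at least 3.7-fold higher number from compound 1 to compound 3 (0.57 log units; beyond the scatter) and the step of an at least 3.5-fold higher number from compound 2 to compound 3 (0.55 log units; beyond the scatter) both point to a weaker read-out once the branched 1-(hydroxymethyl)-2-methylpropyl or 1-carboxy-2-methylpropyl group is replaced by a plain 2-carboxyethyl chain.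

Compound 4 `CCn1c(C(=O)N[C@H](CC(=O)O)C(=O)O)ccc1C(CC)(CC)c1ccc(OCS(=O)(=O)c2ccccc2)c(C)c1` is not yet measured. It differs from compound 1 by 1,2-dicarboxyethyl in place of 1-(hydroxymethyl)-2-methylpropyl on an amide-type nitrogen. The carboxy for hydroxymethyl part of this change should be neutral, as the step of a 1.1-fold higher number from compound 1 to compound 2 (0.02 log units; within the scatter) was within the scatter, but the loss of the branched group resembles the step of an at least 3.7-fold higher number from compound 1 to compound 3 (0.57 log units; beyond the scatter), which was beyond it. The expected step of a 2.7-fold higher number from compound 1 to compound 4 (0.42 log units; beyond the scatter) therefore is toward a higher number. Compound 4 is estimated at 35000 nM in this assay, with a likely range from 14000 nM to 100000 nM.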

Compound 4, half-maximal inhibitory concentration: > 50000 nM
Compound 4: no number, only a limit; the forecaster's own chance of this, stated with the estimate: 50%; middle value at least 1.4-fold (0.15 log units) away from the limit.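

In this assay compound 4 gives > 50000 nM, which is a limit and not a number. The step of an at least 3.5-fold higher number from compound 2 to compound 4 (0.55 log units; beyond the scatter) is the new information: with the carboxy kept on the saturated chain carbon bound to an amide-type nitrogen and a carbonyl carbon, carboxymethyl in place of isopropyl is enough to give a weaker read-out, and the step of an at least 3.7-fold higher number from compound 1 to compound 4 (0.57 log units; beyond the scatter) agrees with this. Compound 3 and compound 4 both stop at the limit, so the step between them cannot be read: the limit of > 50000 nM in this assay, at which 2 of the 4 values shown sit.

As far as these compounds go, what stays open is whether the isopropyl group itself matters or whether other groups on that carbon would hold the number near that of compound 2. An isobutyl chain, a primary carboxamide or an aminomethyl group in place of carboxymethyl would separate these cases.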